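The compounds below may be only part of what the source reports. "The series", "measured", "known", "first", "only" and "open" are said of these compounds alone.

Among the compounds with values here, compound 2 `O=C(c1cccnc1)N1CCC(NS(=O)(=O)c2cc(S(=O)(=O)c3ccccc3)ccc2C(F)(F)F)CC1` gives the lower of the two numbers measured so far in an assay on U2OS cells for inhibition of secreted frizzled-related protein 1 (Homo sapiens), read by a luciferase reporter, with a stated time of 18 h; on this read-out lower numbers stand for an effect already at smaller amounts and higher numbers for an effect only at larger amounts of compound: compound 2 gives 120 nM, while compound 1 `O=C(c1ccccc1)N1CCC(NS(=O)(=O)c2cc(S(=O)(=O)c3ccccc3)ccc2C(F)(F)F)CC1` gives 250 nM. Within the data shown here, the single step between them, a 2.1-fold lower number from compound 1 to compound 2 (0.32 log units; beyond the scatter), is modest and concerns an exchange of the whole ring on the carbonyl carbon. Compound 3 `O=C(c1ccc(Cl)nc1)N1CCC(NS(=O)(=O)c2cc(S(=O)(=O)c3ccccc3)ccc2C(F)(F)F)CC1` keeps the pyridin-3-yl ring of compound 2 and carries one additional substituent: chloro in place of hydrogen on an aromatic carbon. Among the measured compounds shown here, no measured step shows what a substituent on that ring does. The change from compound 1 to compound 2 altered the ring itself and bears on compound 3 only in a general sense: modifications around this carbonyl have so far moved the number in this assay within a modest range. The expectation for this assay is a step of about that size or none beyond the scatter, expressed as a 1.2-fold lower number from compound 2 to compound 3 (0.08 log units; within the scatter). Compound 3 is expected to give 100 nM in this assay, with a range from 40 nM to 300 nM.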

Compound 3, half-maximal effective concentration: 140 nM
Estimate against measurement, compound 3: 1.4-fold (0.15 log units) below; the measured number falls inside the stated range.
By their numbers in this assay, from the lowest: compounds 2, 3 and 1 (each within the scatter of the next, the first and the last beyond it).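

In this assay, within the data shown here, chloro in place of hydrogen on the aromatic carbon next to the ring nitrogen amounts to a 1.2-fold higher number from compound 2 to compound 3 (0.07 log units; within the scatter), so this position of the pyridin-3-yl ring accepts a chloro with no step that can be told from the usual scatter. Read against the phenyl compound, the exchange for 6-chloropyridin-3-yl gives a 1.8-fold lower number from compound 1 to compound 3 (0.25 log units; within the scatter), which also stays within the scatter, whereas the earlier exchange for the unsubstituted ring gave a 2.1-fold lower number from compound 1 to compound 2 (0.32 log units; beyond the scatter), just beyond it. No measurement at hand accounts for the absence of a clear step at this position.

The compounds shown leave open whether other groups on the same carbon, such as a methoxy group, an amine or a carboxylic acid, would also stay within the scatter of compound 2 or would give a clear step. They also leave open whether chloro on another carbon of the ring, or on the phenyl ring of compound 1, would behave as it does in compound 3.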